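A few compounds are considered here, and "the series" means these few. Any claim that something is new, unique, unknown or untested is made for them only; others in the source may bear on it.

Measured so far:
- compound 1 `Cc1ccc(Nc2ncc3c(n2)N(C)C(=O)N(c2cc(NC(=O)c4ccc(C)c(C(F)(F)F)c4)ccc2C)C3)cn1`: 870 nM
- compound 2 `Cc1ccc(Nc2ncc3c(n2)N(c2ccccc2)C(=O)N(c2cc(NC(=O)c4ccc(C)c(C(F)(F)F)c4)ccc2C)C3)cn1`: 3300 nM

In an ADME assay on BaF3 cells (Mus musculus) for inhibition, read by CellTiter-Glo, with a stated time of 72 h (a lower number here means a stronger inhibitor of growth, a higher number a weaker inhibitor of growth), compound 1 gives 870 nM, the lower of the two numbers, and compound 2 gives 3300 nM. The next compound to be read is compound 3 `Cc1ccc(Nc2ncc3c(n2)N(C)C(=O)N(c2cc(NC(=O)c4ccc(N5CCN(C)CC5)c(C(F)(F)F)c4)ccc2C)C3)cn1`, which keeps the core of compound 1 and changes one group: 4-methylpiperazin-1-yl in place of methyl on an aromatic carbon. In words, this is 4-methylpiperazin-1-yl in place of methyl on an aromatic carbon, ortho to a trifluoromethyl group and para to a large group.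

For the measured compounds named here, the only measured step, a 3.8-fold higher number from compound 1 to compound 2 (0.58 log units; beyond the scatter), is a modest one and concerns phenyl in place of methyl on an amide-type nitrogen in a ring. That is a different place, so it offers a rough scale but no direction for this change. Going by the values given here, no measured compound varies the group at this position. A step of similar modest size is therefore expected, with a tentative lean towards a lower number and no firm support for that direction from the data. The expected change is a 1.7-fold lower number from compound 1 to compound 3 (0.24 log units; within the scatter). For compound 3 the estimated value in this assay is 500 nM, with an expected range of 100 nM to 2500 nM.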

Compound 3, concentration for 50% growth inhibition: 685 nM
Beside the measured number, compound 3's estimate is 1.4-fold (0.14 log units) below it; the range from low to high includes it.
By their numbers in this assay, from the lowest: compounds 3 and 1 (each within the scatter of the next); then compound 2.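

In this assay, the aromatic carbon ortho to a trifluoromethyl group and para to a large group takes 4-methylpiperazin-1-yl in place of methyl with the two compounds reading alike: a 1.3-fold lower number from compound 1 to compound 3 (0.10 log units; within the scatter). For the compounds shown here, this is the first information on this position, since the earlier pair varied only the amide-type nitrogen in a ring, and it shows that a substituent as large as this one, with its six-membered non-aromatic ring and 2 hetero atoms, can sit here without a loss of growth inhibition beyond the scatter. Nothing measured here accounts for this result.

Going by these compounds, one step cannot show how this position responds in general, so the readings for a morpholine ring, a primary amine or a carboxylic acid on this carbon remain open. On these data alone, it is also open whether 4-methylpiperazin-1-yl reads the same when phenyl stands in place of methyl on the amide-type nitrogen in a ring, and whether a shorter chain such as dimethylamino would do as well as the full ring.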